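Remote aryl-to-alkyl swap in a quinoline amine series

The source may report more compounds than this note shows. Statements on the series, on what has been measured and on what is new or still open speak of the compounds shown alone.

Measured compounds:
compound 1 `COc1cccc(CNCCCNc2ccnc3cc(Oc4ccc(Cl)cc4)ccc23)c1O` — 9.28
compound 2 `COc1cccc(CNCCCNc2ccnc3cc(-c4ccc(C(F)(F)F)cc4)ccc23)c1O` — 9.47

The two compounds were measured in a physicochemical assay for acid dissociation. Compound 2 has the higher of the two numbers, but the nearest neighbour, compound 1, lies only a number 0.19 log units higher from compound 1 to compound 2 (within the scatter), so the two values cannot be told apart. That single step swapped one group for another at the same aromatic carbon of the shared core and left the acid dissociation constant essentially unchanged.

Compound 3 `COc1cccc(CNCCCNc2ccnc3cc(CCC(C)C)ccc23)c1O` has not yet been measured in this assay. It differs from compound 2 as follows: isopentyl in place of 4-(trifluoromethyl)phenyl on an aromatic carbon. Among the compounds with values here, the only measured step that bears on this change is the one from compound 1 to compound 2, which also exchanged the group on this same aromatic carbon and moved the number by an amount within the scatter. On that basis, the step expected here, a number 0.07 log units lower from compound 2 to compound 3 (within the scatter), is one that stays within the scatter, and it is not expected to lean toward either a higher or a lower read-out. Compound 3 is therefore estimated at 9.4, with a range from 9 to 9.8.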

Compound 3, acid dissociation constant: 9.47
Compound 3: the middle estimate sits 0.07 log units below what was measured, within the range that was stated.
By their numbers in this assay, from the lowest: compounds 1, 2 and 3 (each within the scatter of the next).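

In this assay, the earlier pair had only shown one ring-bearing group exchanged for another on this aromatic carbon. The new result extends that to a group with no ring: isopentyl, with 5 heavy atoms, replaces 4-(trifluoromethyl)phenyl, with 10 heavy atoms and a six-membered aromatic ring, and the read-out shows no change at the digits printed from compound 2 to compound 3 (within the scatter). Set against 4-chlorophenoxy, the same isopentyl group gives a number 0.19 log units higher from compound 1 to compound 3 (within the scatter), so across these three compounds neither the presence of an aromatic ring in the group nor the number of its heavy atoms separates the values, and no information is available here to explain this.

The compounds shown leave open whether a group of a different kind on this aromatic carbon, such as an amine, a carboxylic acid or a longer chain, would also stay within the scatter of these three values. They also leave open whether the read-out would hold as steady for a change made anywhere else on the shared core.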